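The source may hold more compounds than are shown below. What is called first, only, known or untested is meant among the compounds shown, and "the series" means these compounds.

Measured compounds:
compound 1 `CCCN(CCC)Cc1ccc(Cl)c(-c2ccccc2OC)c1`; compound 2 `COc1ccccc1-c1cc(C2CCN(C)C2)ccc1Cl`

In an assay on isolated protein for binding affinity to 5-hydroxytryptamine receptor 1E (Homo sapiens) (a lower number here means a stronger inhibitor, a higher number a weaker inhibitor), compound 1 gives only a limit, > 10000 nM. In this assay, among the compounds with values here, compound 2 gives 4100 nM, the only firm number in the set. The value of compound 1 is a limit (the limit of > 10000 nM in this assay, at which 1 of the 2 values shown sits). Compound 3 `CCN(CC)Cc1ccc(Cl)c(-c2ccccc2OC)c1` is not yet measured and differs from compound 2 by (diethylamino)methyl in place of 1-methylpyrrolidin-3-yl on an aromatic carbon, an open-chain amine in place of the ring. The step from compound 2 to compound 3 is expected to weaken binding in this assay, a 2.0-fold higher number from compound 2 to compound 3 (0.29 log units; within the scatter), since compound 1 gives > 10000 nM. Compound 3 is therefore estimated at 8000 nM, between 3000 nM and 20000 nM.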

Compound 3, inhibition constant: > 10000 nM
Compound 3: a limit, no number; the forecaster's own chance of this, stated with the estimate: 40%; middle value at least 1.2-fold (0.09 log units) away from the limit.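

In this assay, the change from the 1-methylpyrrolidin-3-yl ring to an open-chain amine on this aromatic carbon now has a readable size, an at least 2.4-fold higher number from compound 2 to compound 3 (0.38 log units; beyond the scatter). For compound 3 the result is only a limit, and both open-chain compounds share it: the limit of > 10000 nM in this assay, at which 2 of the 3 values shown sit. The step between the dipropylamino and diethylamino groups therefore cannot be read.

Going by these compounds, how far the open-chain amines lie from each other remains open. So does whether a piperidine ring or a pyrrolidine without the N-methyl group at this position would bind more strongly than compound 2.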